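This account rests on a few compounds, and the source may have more. Where it says the series, first, only, none or still open, it means among the compounds named here.

In a functional assay on HL-60 cells (Homo sapiens) for inhibition (on this read-out higher numbers stand for weaker inhibition of growth and lower numbers for stronger inhibition of growth), compound 1 (`C=C(C)C(=O)c1ccc(OCc2nc(C)no2)cc1C`) gives 3820 nM and compound 2 (`C=C(C)C(=O)c1ccc(OCc2nc(-c3ccccc3)no2)cc1C`) gives 6700 nM. Compound 3 (`C=C(C)C(=O)c1ccc(OCc2nc(C)no2)cc1Cl`) gives 9700 nM, within the scatter of compound 2 and beyond the scatter of compound 1. Compound 4 (`C=C(C)C(=O)c1ccc(OCc2nc(-c3ccccc3)no2)cc1Cl`) differs from compound 3 by phenyl in place of methyl on an aromatic carbon. The same exchange appears in a 1.8-fold higher number from compound 1 to compound 2 (0.24 log units; within the scatter), a step within the scatter. The exchange of methyl for chloro, a 2.5-fold higher number from compound 1 to compound 3 (0.40 log units; beyond the scatter), is modest and gives the chloro starting point. For the measured compounds named here, no measurement yet shows the phenyl exchange in a chloro compound. No step beyond the scatter is expected in this assay, and the estimated step is a 1.4-fold higher number from compound 3 to compound 4 (0.16 log units; within the scatter). The estimate for compound 4 is 14000 nM, with an expected range of 6500 nM to 28000 nM.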

Compound 4, concentration for 50% growth inhibition: 5400 nM
Estimate against measurement, compound 4: 2.6-fold (0.41 log units) above; the whole stated range lies above it.
By their numbers in this assay, from the lowest: compounds 1, 4, 2 and 3 (each within the scatter of the next, the first and the last beyond it).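

In this assay, phenyl in place of methyl on the aromatic carbon of the five-membered ring gives a 1.8-fold lower number from compound 3 to compound 4 (0.25 log units; within the scatter), so neither core shows a step beyond the scatter for this change. Even so, the exchange does not transfer as a constant step between the methyl and chloro cores: the same change on two cores in this assay, a 1.8-fold higher number (0.24 log units; within the scatter) from compound 1 to compound 2 and a 1.8-fold lower number (0.25 log units; within the scatter) from compound 3 to compound 4, 3.2-fold (0.50 log units) apart, beyond the scatter of two such steps The chloro exchange, a 1.2-fold lower number from compound 2 to compound 4 (0.09 log units; within the scatter), likewise depends on the group at that carbon: the same change on two cores in this assay, a 2.5-fold higher number (0.40 log units; beyond the scatter) from compound 1 to compound 3 and a 1.2-fold lower number (0.09 log units; within the scatter) from compound 2 to compound 4, 3.2-fold (0.50 log units) apart, beyond the scatter of two such steps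

Each comparison rests on a single pair of steps, and the four compounds do not show what underlies the mismatch. On these data alone, whether it persists with an amine or a carboxylic acid at this carbon remains open.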